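Sulfone core: methylsulfanyl for trifluoromethyl

This account rests on a few compounds, and the source may have more. Where it says the series, first, only, none or still open, it means among the compounds named here.

Compound 1 `N#Cc1cc(C(=O)N2CS(=O)(=O)c3ccccc32)cc(C(F)(F)F)c1O` was tested in an assay on tissue (RPTEC cells) for inhibition of solute carrier family 22 member 12 (Homo sapiens), read by scintillation counting, with stated times of 15 min and 2 h; on this read-out lower numbers stand for stronger inhibition and higher numbers for weaker inhibition. In this assay compound 1 returns only a limit, > 100000 nM. Compound 2 `N#Cc1cc(C(=O)N2CSc3ccccc32)cc(C(F)(F)F)c1O` gives 13100 nM in this assay. Compound 1 thus stands at the limit of > 100000 nM in this assay, at which 1 of the 2 values shown sits, with no number of its own. Compound 3 `CSc1cc(C(=O)N2CS(=O)(=O)c3ccccc32)cc(C#N)c1O` differs from compound 1 by methylsulfanyl in place of trifluoromethyl on an aromatic carbon, ortho to a hydroxy group. Within the data shown here, no measured step tells the size of such a change. Expected is a step of an at least 1.6-fold lower number from compound 1 to compound 3 (0.22 log units; that floor lies within the scatter), not beyond the scatter. Compound 3 is estimated at 60000 nM, between 10000 nM and 300000 nM, and may again come back as a limit.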

Compound 3, half-maximal inhibitory concentration: 7100 nM
For compound 3 the middle estimate is 8.5-fold (0.93 log units) above the measured one; the measured number lies below the stated range.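

In this assay, methylsulfanyl in place of trifluoromethyl on an aromatic carbon, ortho to a hydroxy group, gives an at least 14-fold lower number from compound 1 to compound 3 (1.14 log units; beyond the scatter). Among these compounds, this position therefore responds strongly to a single exchange on the core of compound 1, which the earlier compounds could not show. Compound 1 holds only a limit, so the step is a floor and its full size stays unread: the limit of > 100000 nM in this assay, at which 1 of the 3 values shown sits.

Going by these compounds, whether another group here, such as an amine, a methoxy group or a longer thioether chain, would serve as well stays open. Also open, on these data alone, is whether the same exchange would act alike on the core of compound 2, which gives 13100 nM with trifluoromethyl.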